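The source may report more compounds than this note shows. Statements on the series, on what has been measured and on what is new or still open speak of the compounds shown alone.

Compound 2 `Cc1nc(S(C)(=O)=O)ccc1Oc1ncnc(OC2CCN(C(=O)O[C@@H](C)C(F)(F)F)CC2)c1F` gives 80% in a functional assay on isolated protein for inhibition of Glucose-dependent insulinotropic receptor (Rattus norvegicus), read by HTRF and cAMP accumulation; a lower number here means a smaller maximal response, a higher number a larger maximal response. Against compound 1 `Cc1nc(S(C)(=O)=O)ccc1Oc1ncnc(OC2CCN(C(=O)OC(C)(C)CF)CC2)c1F`, which gives 95%, the step is a number 15 percentage points lower from compound 1 to compound 2 (beyond the scatter); compound 3 `Cc1nc(S(C)(=O)=O)ccc1Oc1ncnc(OC2CCN(C(=O)SC(C)C)CC2)c1F`, which gives 81%, lies within the scatter of compound 2, the step being a number 1 percentage points higher from compound 2 to compound 3 (within the scatter). Compound 4 `Cc1nc(S(C)(=O)=O)ccc1Oc1ncnc(OC2CCN(C(=O)SC3CCC3)CC2)c1F` differs from compound 2 in one place: cyclobutylsulfanyl in place of 1-(trifluoromethyl)ethoxy on a carbonyl carbon. The step from compound 2 to compound 3 bears most directly on this change, since there too a sulfanyl group replaced the 1-(trifluoromethyl)ethoxy group, and it brought a number 1 percentage points higher from compound 2 to compound 3 (within the scatter); the step of a number 14 percentage points lower from compound 1 to compound 3 (beyond the scatter) shows the same sulfanyl group sitting with compound 2. No step beyond the scatter is therefore expected, and compound 4 is estimated at 82%, between 70% and 93%, a change of a number 2 percentage points higher from compound 2 to compound 4 (within the scatter).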

Compound 4, largest response reached (reported as efficacy), in percent of the reference or control that the assay uses: 81%
Beside the measured number, compound 4's estimate is 1 percentage points above it, and the stated range covers the measured number.
By their numbers in this assay, from the lowest: compounds 2, 3 and 4 (each within the scatter of the next); then compound 1.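

In this assay, a ring on the sulfur reads like the open isopropyl group: cyclobutyl in place of isopropyl gives no change at the digits printed from compound 3 to compound 4 (within the scatter) and so adds nothing to the earlier sulfanyl result. The step of a number 1 percentage points higher from compound 2 to compound 4 (within the scatter) also stays within the scatter, while a number 14 percentage points lower from compound 1 to compound 4 (beyond the scatter) shows that the second sulfanyl group, too, remains apart from compound 1. No measurement at hand offers an explanation for these results. From the compounds shown here alone, whether any sulfanyl group on this carbonyl carbon can match compound 1 stays open, as does how a longer chain such as n-butylsulfanyl or an amine there would read.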